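The source may report more compounds than this note shows. Statements on the series, on what has been measured and on what is new or still open speak of the compounds shown alone.

In a functional assay on U-251 cells (Homo sapiens) for antiproliferative activity, read by MTT assay, with a stated time of 48 h (on this read-out lower numbers stand for stronger inhibition and higher numbers for weaker inhibition), compound 2 `COc1cc(-c2cccc3nc(-c4ccc(C)cc4)oc23)cc(OC)c1OC` gives 3200 nM, the lower of the two actual numbers, and compound 3 `COc1ccc(-c2cccc3nc(-c4ccc5cc[nH]c5c4)oc23)c(OC)c1OC` gives 9500 nM. Compound 1 `COc1cc(-c2cccc3nc(-c4ccc(Br)cc4)oc23)cc(OC)c1OC` reaches only a limit of the assay, > 25000 nM. Compound 4 `COc1cc(-c2cccc3nc(-c4cccs4)oc23)cc(OC)c1OC` carries thiophen-2-yl in place of 4-methylphenyl on an aromatic carbon. Among the measured compounds shown here, the only measured step that bears on this is an at least 7.8-fold lower number from compound 1 to compound 2 (0.89 log units; beyond the scatter), with methyl in place of bromo on an aromatic carbon. For the measured compounds named here, that step shows compound 2 responding to a change within the group now replaced, although no measured step swaps the whole ring. A modest rise is therefore expected, and the expected step is a 1.7-fold higher number from compound 2 to compound 4 (0.24 log units; within the scatter). For compound 4 the estimated value is 5500 nM, with an expected range of 1800 nM to 18000 nM.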

Compound 4, half-maximal inhibitory concentration: 3000 nM
The estimate for compound 4 lay 1.8-fold (0.26 log units) above the measured number, and the stated range covers the measured number.
By their numbers in this assay, from the lowest: compounds 4 and 2 (each within the scatter of the next); then compound 3. At a limit, above all of these: compound 1.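

In this assay, replacing the whole 4-methylphenyl ring with thiophen-2-yl gives a 1.1-fold lower number from compound 2 to compound 4 (0.03 log units; within the scatter), so this position tolerates a five-membered aromatic ring with a sulfur atom in place of the six-membered carbon ring, which the earlier change within the phenyl group could not show. Set against 4-bromophenyl, the same ring gives an at least 8.3-fold lower number from compound 1 to compound 4 (0.92 log units; beyond the scatter). Compound 1 stands only at a limit, so that step has no fixed size: the limit of > 25000 nM in this assay, at which 1 of the 4 values shown sits.

The compounds shown leave open whether an amine or a carboxylic acid on the ring at this position would keep this level of activity.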